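A Benzyl Group Replaces Cyclohexyl on the Imine Nitrogen

The source may report more compounds than this note shows. Statements on the series, on what has been measured and on what is new or still open speak of the compounds shown alone.

Three measured compounds share one core and differ only in the group on a double-bonded nitrogen: compound 1 `O=C(NC1CC1)OC[C@H]1OC(n2cnc3c(NC4CCOC4)ncnc32)[C@H](O)[C@@H]1O`, compound 2 `O[C@@H]1[C@@H](CO/C(S)=N/C2CC2)OC(n2cnc3c(NC4CCOC4)ncnc32)[C@@H]1O` and compound 3 `O[C@@H]1[C@@H](CO/C(S)=N/C2CCCCC2)OC(n2cnc3c(NC4CCOC4)ncnc32)[C@@H]1O`. In an assay on DDT1 cells (Cricetulus griseus) for binding affinity to adenosine receptor A1 (Homo sapiens), read by radioligand binding (on this read-out lower numbers stand for stronger inhibition and higher numbers for weaker inhibition), compound 1 gives 209 nM, compound 2 gives 157 nM and compound 3 gives 253 nM. Compound 3 holds the highest of the three numbers, yet a 1.2-fold higher number from compound 1 to compound 3 (0.08 log units; within the scatter) and a 1.6-fold higher number from compound 2 to compound 3 (0.21 log units; within the scatter) both sit within the scatter, as does a 1.3-fold lower number from compound 1 to compound 2 (0.12 log units; within the scatter). Compound 4 `O[C@@H]1[C@@H](CO/C(S)=N/Cc2ccccc2)OC(n2cnc3c(NC4CCOC4)ncnc32)[C@@H]1O` carries benzyl in place of cyclohexyl on a double-bonded nitrogen. Among the measured compounds shown here, no measured step exchanges a non-aromatic ring for an aromatic one; the nearest comparison, a 1.6-fold higher number from compound 2 to compound 3 (0.21 log units; within the scatter), altered ring size without leaving the scatter. The number for compound 4 is therefore expected near 250 nM, with a range from 120 nM to 520 nM. The expected step of a 1.0-fold lower number from compound 3 to compound 4 (0.01 log units; within the scatter) would not exceed the scatter.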

Compound 4, inhibition constant: 12 nM
Compound 4: the middle estimate sits 21-fold (1.32 log units) above what was measured; measured number outside the range, below it.
By their numbers in this assay, from the lowest: compound 4; then compounds 2, 1 and 3 (each within the scatter of the next).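

In this assay the group on the double-bonded nitrogen proves able to move the number well beyond the scatter: benzyl stands apart from cyclohexyl (a 21-fold lower number from compound 3 to compound 4 (1.32 log units; beyond the scatter)) and from cyclopropyl (a 13-fold lower number from compound 2 to compound 4 (1.12 log units; beyond the scatter)), and compound 4 also stands apart from the oxygen-linked compound (a 17-fold lower number from compound 1 to compound 4 (1.24 log units; beyond the scatter)). The two non-aromatic rings had stayed within the scatter of each other, so this position tolerates some exchanges without change but responds strongly to this one. Nothing available accounts for the difference.

Going by these compounds, what remains open is whether the aromatic ring or the added carbon carries the step. Phenyl, cyclohexylmethyl or 2-phenylethyl on that nitrogen would separate the two.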